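Notes on replacing the amide aryl group of compound 2

This account rests on a few compounds, and the source may have more. Where it says the series, first, only, none or still open, it means among the compounds named here.

Measured so far:
- compound 1 `O=C(Nc1cc(-c2ccccc2)nn1-c1ccccc1)c1ccc(F)cc1`; in an assay on isolated protein with metabotropic glutamate receptor 5 (Rattus norvegicus) as the target (on this read-out lower numbers stand for an effect already at smaller amounts and higher numbers for an effect only at larger amounts of compound), compound 1 gives 50 nM
- compound 2 `O=C(Nc1cc(-c2ccccc2)nn1-c1ccccc1)c1ccc(C(F)(F)F)cc1`; in this assay compound 2 gives 20 nM

Among the measured compounds shown here, compound 2 holds the lowest of the two numbers; the only other point is compound 1, and the step of a 2.5-fold lower number from compound 1 to compound 2 (0.40 log units; beyond the scatter) separates them, beyond the scatter.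

The next compound, compound 3 `O=C(Nc1cc(-c2ccccc2)nn1-c1ccccc1)c1ccsc1`, differs from compound 2 in a single place: thiophen-3-yl in place of 4-(trifluoromethyl)phenyl on a carbonyl carbon. The whole benzene ring carrying the trifluoromethyl group is thus exchanged for a five-membered aromatic ring with one hetero atom and one hydrogen-bond acceptor.

For the measured compounds named here, only one measured step exists, a 2.5-fold lower number from compound 1 to compound 2 (0.40 log units; beyond the scatter), and it touches just the substituent on the aromatic ring, not the ring itself. It shows that what sits on that ring matters for this assay by a modest but real amount. Going by the values given here, removing that ring, and with it the trifluoromethyl group, is a larger departure than either measured compound covers, so no step is known that maps directly onto it. On balance the expectation is an increase in the number for compound 3 relative to compound 2, with wide uncertainty.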

Compound 3, half-maximal effective concentration: 2900 nM
The estimate for compound 3 lay 29-fold (1.46 log units) below the measured number; measured number outside the range, above it.
By their numbers in this assay, from the lowest: compound 2; then compound 1; then compound 3.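

In this assay, the exchange of the whole aryl group on the carbonyl carbon weighs far more than the exchange of a substituent on that group (a 2.5-fold lower number from compound 1 to compound 2 (0.40 log units; beyond the scatter)). Thiophen-3-yl gives a large step against 4-(trifluoromethyl)phenyl (a 150-fold higher number from compound 2 to compound 3 (2.16 log units; beyond the scatter)) and also against 4-fluorophenyl (a 58-fold higher number from compound 1 to compound 3 (1.76 log units; beyond the scatter)), so among these three compounds this position tolerates the ring exchange poorly, whichever of the two substituted phenyl groups is the reference. No evidence is available on what lies behind the size of these steps.

The single change in compound 3 alters ring size, brings in sulfur and removes the substituent all at once, and the compounds shown do not separate these contributions. Open questions are where unsubstituted phenyl would fall, and whether a thiophen-3-yl carrying trifluoromethyl, a thiophen-2-yl or a pyridine ring would stay near compound 3 or return towards compound 1 and compound 2.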